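The source may hold more compounds than are shown below. What is called first, only, known or untested is meant among the compounds shown, and "the series" means these compounds.

This account follows a single change made to compound 1 `Nc1nc(N)c2c(/C=C\c3ccc4ccccc4c3)cccc2n1` and asks what it should do to potency in an assay for inhibition of Dihydrofolate reductase (Homo sapiens); on this read-out higher numbers stand for higher potency (the scale is a negative logarithm) and lower numbers for lower potency. Among the three measured compounds, compound 1 gives 6.52 in this assay, the second highest of the three numbers. Compound 2 `Nc1nc(O)c2cc(Sc3ccc4ccccc4c3)ccc2n1` gives 7.35 in this assay, a number above that of compound 1 by a gap beyond the scatter. Compound 3 `Nc1ncnc2ccc(Sc3ccc4ccccc4c3)cc12` gives 4.68 in this assay, a number below that of compound 1 by a gap that is also beyond the scatter. Neither compound 2 nor compound 3 differs from compound 1 in one place only, so these two values frame where compound 1 stands and say nothing about the step in question.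

Compound 4 `Nc1nc(N)c2c(/C=C/c3ccc4ccccc4c3)cccc2n1` differs from compound 1 as follows: the two compounds have the same atoms and bonds and differ only in configuration as drawn: 1 of 1 stereo elements differ; a double bond is drawn Z in compound 1 and E in compound 4. For the measured compounds named here, nothing among the measured compounds shows how a change of drawn configuration alone affects this assay. Only the geometry as drawn changes, so the step is expected to be modest, most likely not beyond the scatter, with a slight lean upward. The step the estimate means, expected to stay within the usual scatter, is a number 0.18 log units higher from compound 1 to compound 4 (within the scatter). Compound 4 is accordingly expected to give 6.7 in this assay, within a range from 6 to 7.4.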

Compound 4, logarithm of the reciprocal of the active concentration, log(1/C): 5.28
Compound 4: middle estimate off by 1.42 log units, on the high side, outside the stated range (below it).
By their numbers in this assay, from the lowest: compound 3; then compound 4; then compound 1; then compound 2.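

In this assay, going from the Z to the E double bond gives a number 1.24 log units lower from compound 1 to compound 4 (beyond the scatter), so the geometry as drawn at this double bond is enough by itself to move potency by a large step. The earlier compounds shown here could not show this, since neither compound 2 nor compound 3 differs from compound 1 in one place only, and their values only framed where compound 1 stands. The drop can be assigned to configuration rather than to any gain or loss of atoms, because nothing else separates the two compounds: the fact that compounds 1 and 4 differ only in the configuration as drawn.

Why the Z form as drawn stands higher remains open, as the pair gives the size and direction of the step but no reason for it, and it is a single pair on a single core. Also open, as far as these compounds go, is whether an amide in place of the double bond would hold potency near that of compound 1 or fall toward that of compound 4, and whether the same gap between the two geometries would persist with a different group on the far end of the double bond, such as a simple phenyl.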